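Trimming a Side Chain: From Sec-Butyl to Isopropyl

The compounds below may be only part of what the source reports. "The series", "measured", "known", "first", "only" and "open" are said of these compounds alone.

Of the compounds shown here, three built on one shared core have been measured in a functional assay for inhibition, read by spectrophotometry, with a stated time of 20 min, tested at 5 mg/mL; on this read-out higher numbers stand for a stronger effect at the one concentration tested and lower numbers for a weaker effect. Compound 2 `CC(=O)c1ccc(NC(=O)C(CC(C)C)N(C(=O)c2ccccc2)S(=O)(=O)c2ccccc2)cc1` gives 52.2%. Compound 1 `CC(=O)c1ccc(NC(=O)C(C(C)C)N(C(=O)c2ccccc2)S(=O)(=O)c2ccc([N+](=O)[O-])cc2)cc1` gives 27.4%. Compound 3 `CCC(C)C(C(=O)Nc1ccc(C(C)=O)cc1)N(C(=O)c1ccccc1)S(=O)(=O)c1ccccc1` gives 16.8%, the lowest of the three numbers; its nearest neighbour is compound 1 and its furthest is compound 2. Among the compounds with values here, the only step between measured compounds that differ in one place is a number 35.4 percentage points lower from compound 2 to compound 3 (beyond the scatter), a large loss that came with a different branching of the side chain.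

Compound 4 `CC(=O)c1ccc(NC(=O)C(C(C)C)N(C(=O)c2ccccc2)S(=O)(=O)c2ccccc2)cc1` is the next compound. Its difference from compound 3 is hydrogen in place of methyl on a saturated chain carbon, three bonds along the chain from an amide-type nitrogen and a carbonyl carbon. Within the data shown here, no measured step covers this exact change. Among the measured compounds shown here, the one step that does exist, a number 35.4 percentage points lower from compound 2 to compound 3 (beyond the scatter), shows that reshaping this side chain can move the read-out a great deal, so a sizeable shift is possible. Compound 1 carries the same isopropyl side chain as compound 4, although it differs elsewhere, and compound 1 with 27.4% sits higher than compound 3. Compound 4 is therefore expected to come in at 28%, within 12% to 46%. For compound 4 this estimate amounts to an expected step of a number 11.2 percentage points higher from compound 3 to compound 4 (beyond the scatter), a moderate rise.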

Compound 4, a percentage reported as inhibition, at one concentration (the size of the read-out at that concentration, not a potency): 54.2%
Estimate against measurement, compound 4: 26.2 percentage points below; the measured number lies above the stated range.
By their numbers in this assay, from the lowest: compound 3; then compound 1; then compounds 2 and 4 (each within the scatter of the next).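

In this assay the change from sec-butyl to isopropyl brings a number 37.4 percentage points higher from compound 3 to compound 4 (beyond the scatter) while isopropyl in place of isobutyl brings only a number 2 percentage points higher from compound 2 to compound 4 (within the scatter) and so, among these three side chains, sec-butyl alone stands apart from the other two. Hydrogen in place of nitro on an aromatic carbon brings a number 26.8 percentage points higher from compound 1 to compound 4 (beyond the scatter) with the isopropyl side chain held the same, which shows that this second place also moves the read-out and that the number for compound 1 did not speak for the isopropyl side chain alone. Nothing at hand says why the read-out responds to either change in this way.

The compounds shown leave open how a longer straight chain such as n-butyl, a ring such as cyclohexyl, or a side chain ending in an amine or a carboxylic acid would behave on this saturated chain carbon. They also leave open whether a methoxy group or a chlorine in place of nitro on the aromatic carbon would follow compound 1 or compound 4, and each number is the size of the effect at one concentration, not a potency.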